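The source may report more compounds than this note shows. Statements on the series, on what has been measured and on what is new or still open speak of the compounds shown alone.

Measured compounds in an ADME assay on Vero cells (Chlorocebus sabaeus) for cytotoxicity; a lower number here means that less compound is tolerated, a higher number that more compound is tolerated:
compound 1, `COc1ccc(-c2nc3cc([N+](=O)[O-])ccc3[nH]2)c(OC)c1OC`: > 100000 nM
compound 2, `CC(=O)Nc1ccc(-c2nc3cc([N+](=O)[O-])ccc3[nH]2)cc1`: > 100000 nM

The value given for compound 1 is a limit of the assay, not a number. For compound 2 the value > 100000 nM is likewise a limit of the assay and not a number. Compound 2 thus stands at the limit of > 100000 nM in this assay, at which 2 of the 2 values shown sit, with nothing that separates it from compound 1. Compound 3, `CC(=O)Nc1ccc(-c2nc3cc(C(F)(F)F)ccc3[nH]2)cc1`, is not yet measured; it differs from compound 2 by trifluoromethyl in place of nitro on an aromatic carbon. In this assay no step beyond the scatter is expected from this change. For compound 3 the expected value is 100000 nM, between 40000 nM and 300000 nM. The estimated step is a number no higher from compound 2 to compound 3 (the limit leaves the size open).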

Compound 3, half-maximal cytotoxic concentration: 50000 nM
Beside the measured number, compound 3's estimate is 2.0-fold (0.30 log units) above it, within the range that was stated.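

In this assay, trifluoromethyl at this position gives the first number rather than a limit, with compound 3 at 50000 nM. As far as these compounds go, replacing nitro here gives an at least 2.0-fold lower number from compound 2 to compound 3 (0.30 log units; that floor lies within the scatter), and this is only a floor, so the true size of the change stays open. Compound 2 remains at a limit of the assay: the limit of > 100000 nM in this assay, at which 2 of the 3 values shown sit.

From the compounds shown here alone, whether an amine or a carboxylic acid at this position would give a number or a limit remains open. So does whether the same replacement on the core of compound 1 would read alike.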